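Swapping the Benzyl Group on a Shared Core

The compounds below may be only part of what the source reports. "The series", "measured", "known", "first", "only" and "open" are said of these compounds alone.

For the measured compounds named here, in an ADME assay on HepG2 cells (Homo sapiens) for cytotoxicity, read by luminescence, CellTiter-Glo and ATP content, with a stated time of 72 h (on this read-out lower numbers stand for an effect already at smaller amounts and higher numbers for an effect only at larger amounts of compound), compound 3 `COc1ccc(F)cc1CNCCCNc1ccnc2cc(Cc3ccc(C#N)cc3)ccc12` gives 6050 nM, the highest of the three numbers measured so far. Its nearest neighbour is compound 1 `COc1cccc(CNCCCNc2ccnc3cc(Oc4ccc(Cl)cc4)ccc23)c1O`, which in this assay gives 5700 nM, within the scatter of compound 3. Compound 2 `COc1cccc(CNCCCNc2ccnc3cc(-c4ccc(C(F)(F)F)cc4)ccc23)c1O` lies furthest away: in this assay compound 2 gives 2210 nM, beyond the scatter from compound 3. Going by the values given here, the only measured step between compounds that differ in one place is a 2.6-fold lower number from compound 1 to compound 2 (0.41 log units; beyond the scatter), a modest change at a position that compound 3 and compound 4 hold in common.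

Compound 4 `COc1cccc(CNCCCNc2ccnc3cc(Cc4ccc(C#N)cc4)ccc23)c1O` has not yet been measured. It differs from compound 3 in the benzyl group: 2-hydroxy-3-methoxyphenyl in place of 5-fluoro-2-methoxyphenyl on a saturated chain carbon bound to an amine nitrogen. Compounds 1 and 2 already carry the 2-hydroxy-3-methoxybenzyl group that enters here, so compound 4 shares that part with them and the rest of its structure with compound 3. Among the compounds with values here, no measured step follows this particular change, and the one measured step concerns a different position. Within the data shown here, the values of compound 1 and compound 3, which are within the scatter of each other, are the only guide. The expectation is therefore no step beyond the scatter, a 1.2-fold lower number from compound 3 to compound 4 (0.08 log units; within the scatter). Compound 4 is estimated at 5000 nM in this assay, with a range from 2500 nM to 11000 nM.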

Compound 4, half-maximal effective concentration: 7150 nM
Compound 4: the middle estimate sits 1.4-fold (0.16 log units) below what was measured, and the stated range covers the measured number.
By their numbers in this assay, from the lowest: compound 2; then compounds 1, 3 and 4 (each within the scatter of the next).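

In this assay, for the compounds shown here, the exchange of 5-fluoro-2-methoxyphenyl for 2-hydroxy-3-methoxyphenyl on a saturated chain carbon bound to an amine nitrogen gives a 1.2-fold higher number from compound 3 to compound 4 (0.07 log units; within the scatter) and so, for the first time, puts a number on this position: with the rest of the structure held the same, this swap of the fluorine for a hydroxyl-bearing pattern, with one more hydrogen-bond donor, does not move the read-out past the usual scatter. With the 2-hydroxy-3-methoxybenzyl group held fixed, the aromatic carbon now has two further steps, as 4-cyanobenzyl in place of 4-(trifluoromethyl)phenyl gives a 3.2-fold higher number from compound 2 to compound 4 (0.51 log units; beyond the scatter) and 4-cyanobenzyl in place of 4-chlorophenoxy gives a 1.3-fold higher number from compound 1 to compound 4 (0.10 log units; within the scatter), so among these compounds only compound 2 stands apart from the others. Nothing shown here gives a reason for either the flat step at the benzyl group or the separation of compound 2.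

The compounds shown leave open whether the flat step at the benzyl group holds when the group on the aromatic carbon is 4-(trifluoromethyl)phenyl or 4-chlorophenoxy. They also leave open how the read-out would respond to an amine or a carboxylic acid on the benzyl ring, or to a longer chain at the saturated linker.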